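The compounds below may be only part of what the source reports. "The series", "measured", "known", "first", "only" and "open" are said of these compounds alone.

Measured compounds:
compound 1 `CC[C@@H](Nc1c(C#N)c(-c2ccc(-c3cccc(Cl)c3F)cc2)nc2cnccc12)C(N)=O` — in a physicochemical assay for lipophilicity, read by HPLC, at pH 7.5 (a higher number here means a more lipophilic compound, a lower number a more polar compound), compound 1 gives 3.1
compound 2 `CC[C@@H](Nc1c(C#N)c(-c2ccc(-c3cccc(CO)c3)cc2)nc2cnccc12)C(N)=O` — in this assay compound 2 gives 2

Compound 2 stands lowest of the two numbers; its nearest neighbour is compound 1, and the change is a number 1.10 log units lower from compound 1 to compound 2 (beyond the scatter). Compound 3 `CC[C@@H](Nc1c(C#N)c(-c2ccc(-c3ccccc3CO)cc2)nc2cnccc12)C(N)=O` has the same atoms as compound 2, joined differently: 2-(hydroxymethyl)phenyl in place of 3-(hydroxymethyl)phenyl on an aromatic carbon. Going by the values given here, only one measured step exists, and it swaps one aryl group for another of different atoms, so it bears little on a move of the same group from one place to another on the ring. Among the compounds with values here, the data hold no step between two positional isomers. Compound 3 is therefore expected to show no step beyond the scatter, with no change at the digits printed from compound 2 to compound 3 (within the scatter) as the estimated change. Compound 3 is estimated at 2, within a range from 1.6 to 2.4.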

Compound 3, distribution coefficient: 2.1
Beside the measured number, compound 3's estimate is 0.10 log units below it, within the range that was stated.
By their numbers in this assay, from the lowest: compounds 2 and 3 (each within the scatter of the next); then compound 1.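

In this assay the two hydroxymethyl isomers are not separated: the step reads a number 0.10 log units higher from compound 2 to compound 3 (within the scatter), so for this group the read-out gives no sign that 2-(hydroxymethyl)phenyl and 3-(hydroxymethyl)phenyl differ. The large gap to the 3-chloro-2-fluorophenyl compound is seen again with the new isomer, the step being a number 1.00 log units lower from compound 1 to compound 3 (beyond the scatter), so it appears with the hydroxymethyl group at either of these two placements on the ring. The data at hand offer no independent measurement that would explain either step.

As far as these compounds go, whether the same holds for an aminomethyl group or a carboxylic acid at these two placements remains open. From the compounds shown here alone, it is also open whether a longer chain, such as hydroxyethyl, would leave the two isomers as close together as the hydroxymethyl pair.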